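A few compounds are considered here, and "the series" means these few. Any claim that something is new, unique, unknown or untested is made for them only; others in the source may bear on it.

Measured compounds in a functional assay on the whole organism (strain albino) for inhibition, with Mus musculus as the target, with stated times of 30 min and 5 min, at a dose of 60 mg/kg by the intraperitoneal route; on this read-out lower numbers stand for less inhibition and higher numbers for more inhibition at the one dose given (going by the name of the read-out):
compound 1, `O=c1oc2cc(OCCCN3CCNCC3)ccc2s1`, compound 1 gives 62.3%
compound 2, `O=c1oc2cc(OCCCOc3ccc4ccccc4c3)ccc2s1`, compound 2 gives 47%
compound 3, `O=c1oc2cc(OCCCOc3ccc(Cl)cc3)ccc2s1`, compound 3 gives 49.3%

Of the compounds shown here, three that share one core have been measured. Compound 3 stands second highest of the three. Its nearest neighbour is compound 2, whose number is lower by an amount that lies within the usual scatter of this assay, so no order can be claimed between these two. Compound 1 lies furthest from compound 3, with a number higher by an amount that lies beyond the scatter.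

The next compound, compound 4, `Cc1ccc(OCCCOc2ccc3sc(=O)oc3c2)cc1`, has not yet been measured. It differs from compound 3 in one place: methyl in place of chloro on an aromatic carbon. Going by the values given here, no measured pair shows this change, so its effect can only be guessed. A small step is expected, in no clear direction, not beyond the scatter of the assay. Compound 4 is therefore expected to give about 47%, within a range from 34% to 60%. The expected step of a number 2.3 percentage points lower from compound 3 to compound 4 (within the scatter) is estimated to be small.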

Compound 4, a percentage reported as inhibition, in the whole organism at one dose (the size of the read-out at that dose, not a potency): 52.4%
Estimate against measurement, compound 4: 5.4 percentage points below, and the stated range covers the measured number.
By their numbers in this assay, from the lowest: compounds 2, 3, 4 and 1 (each within the scatter of the next, the first and the last beyond it).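

In this assay, going by these compounds alone, methyl in place of chloro on an aromatic carbon, para to a large group, gives a number 3.1 percentage points higher from compound 3 to compound 4 (within the scatter), the first measured pair to show this change. At this one place, then, going from 4-chlorophenyl to 4-methylphenyl leaves the read-out within the usual scatter, and no order can be claimed between the two compounds. No evidence on hand bears on this result.

On these data alone, it remains open whether another group at the same place, such as an amine, a carboxylic acid or a nitrile, would move the number beyond the scatter. Also open, as far as these compounds go, is whether a longer chain between the shared core and the 4-methylphenyl group would change the number.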